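The source may hold more compounds than are shown below. What is called first, only, known or untested is meant among the compounds shown, and "the series" means these compounds.

The series shares one core, laid out in compound 1 `COC(=O)C[C@H](NC(=O)OC(C)(C)C)C(=O)N(Cc1ccc(F)cc1)C(C)(C)C(=O)NCc1ccccc1`, compound 2 `COC(=O)C[C@H](NC(=O)OC(C)(C)C)C(=O)N(Cc1ccc(F)cc1)C1(C(=O)NCc2ccccc2)CCN(C2CCCCC2)CC1` and compound 3 `COC(=O)C[C@H](NC(=O)OC(C)(C)C)C(=O)NC1(C(=O)NCc2ccccc2)CCN(Cc2ccccc2)CC1`. In an ADME assay on MDCK cells (Canis lupus familiaris) for cytotoxicity, read by microscopy, with a stated time of 72 h (on this read-out higher numbers stand for lower toxicity in this test and lower numbers for higher toxicity in this test), compound 1 gives 20000 nM, compound 2 gives 73000 nM, and compound 3 gives 100000 nM. Compound 3 thus carries the highest of the three numbers; its gap to compound 2 lies within the usual scatter, so no order between those two can be claimed, while its gap to compound 1 lies beyond the scatter.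

Compound 4 `COC(=O)C[C@H](NC(=O)OC(C)(C)C)C(=O)N(Cc1ccc(Cl)cc1)C1(C(=O)NCc2ccccc2)CCN(Cc2ccccc2)CC1` is not yet measured. It differs from compound 3 in a single place: 4-chlorobenzyl in place of hydrogen on an amide-type nitrogen.

Among the measured compounds shown here, no step between measured compounds that differ in only one place is available, so the size of this change has to be judged from the whole set. Compound 2, which also bears a substituent on the same amide-type nitrogen, gives 73000 nM in this assay, a number within the scatter of compound 3. The step from compound 3 to compound 4 is therefore expected to be small, a 1.8-fold lower number from compound 3 to compound 4 (0.26 log units; within the scatter), tending toward a lower number but not clearly beyond the scatter. Compound 4 is estimated to give about 55000 nM in this assay, with a likely range from 18000 nM to 110000 nM.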

Compound 4, minimum cytotoxic concentration: 100000 nM
Beside the measured number, compound 4's estimate is 1.8-fold (0.26 log units) below it, within the range that was stated.
By their numbers in this assay, from the lowest: compound 1; then compounds 2, 3 and 4 (each within the scatter of the next).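

In this assay the amide-type nitrogen whose other neighbours are a carbonyl carbon and a saturated ring carbon takes 4-chlorobenzyl in place of hydrogen with no change at the digits printed from compound 3 to compound 4 (within the scatter) and so accepts a group of 8 heavy atoms, including one six-membered aromatic ring of carbon only, without a change that can be read. Among the compounds shown here, this is the first step in the set between compounds that differ in one place, and it gives a direct reading at this position, where the earlier compounds offered no such pair. Nothing available explains this outcome.

The compounds shown leave open how an amine, a carboxylic acid or a longer chain on this amide-type nitrogen would read in this assay. They also leave open whether plain benzyl or 4-fluorobenzyl would read the same as 4-chlorobenzyl here, and whether this step would hold with a different group elsewhere on the shared core.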